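Swapping Methoxy for Amino on Compound 1

This account rests on a few compounds, and the source may have more. Where it says the series, first, only, none or still open, it means among the compounds named here.

Compound 1 `COc1ccc(Nc2nc(NC3CCCC3)c3ccccc3n2)cc1` is the starting point. In a functional assay on DU-145 cells (Homo sapiens) for antiproliferative activity, read by sulforhodamine B assay, with a stated time of 48 h (a lower number here means a stronger inhibitor of growth, a higher number a weaker inhibitor of growth), compound 1 gives 12400 nM, which places it at the weak end of the three measured compounds, together with compound 3 `COc1ccc(N(C)c2nc(NC3CCCC3)c3ccccc3n2)cc1` at 10200 nM. Compound 2 `CCCNc1nc(Nc2ccc(OC)cc2)nc2ccccc12` stands apart from that pair at 4080 nM.

Compound 4 `Nc1ccc(Nc2nc(NC3CCCC3)c3ccccc3n2)cc1` has not been measured yet. It keeps the rest of compound 1 and makes one change, amino in place of methoxy on an aromatic carbon, para to a large group: amino in place of methoxy on an aromatic carbon.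

Two measured steps offer some guidance, though neither touches this aromatic carbon. Propyl in place of cyclopentyl gives a 3.0-fold lower number from compound 1 to compound 2 (0.48 log units; beyond the scatter), a modest step. Methyl in place of hydrogen on a nitrogen gives a 1.2-fold lower number from compound 1 to compound 3 (0.08 log units; within the scatter). Among the measured compounds shown here, these steps show only how far single changes elsewhere on the shared core have moved the number so far. For the measured compounds named here, no measured compound carries a different group at the place that changes here, so the direction remains open. A small step or none beyond the scatter is therefore expected in this assay. The estimated step is a 1.2-fold lower number from compound 1 to compound 4 (0.09 log units; within the scatter). Compound 4 is expected at about 10000 nM, with an estimated range of 3500 nM to 28000 nM.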

Compound 4, concentration for 50% growth inhibition: 18700 nM
Compound 4: middle estimate off by 1.9-fold (0.27 log units), on the low side; the range from low to high includes it.
By their numbers in this assay, from the lowest: compound 2; then compounds 3, 1 and 4 (each within the scatter of the next).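

In this assay, among the compounds shown here, this is the first measured change at this aromatic carbon, para to a large group, and amino in place of methoxy gives a 1.5-fold higher number from compound 1 to compound 4 (0.18 log units; within the scatter). Going from 4-methoxyphenyl to 4-aminophenyl removes the methoxy group and brings in a hydrogen-bond donor, yet compound 4 cannot be told apart from compound 1 in this assay, so this exchange leaves the growth-inhibition number within the scatter. The shown data give no measurement that accounts for the size of this step.

Amino and methoxy are the only groups compared at this position, so it remains open whether a hydroxy group, a carboxylic acid or a longer chain such as butoxy would move the number beyond the scatter. As far as these compounds go, it is also open whether amino in place of methoxy would give a similar step on compound 2, which carries a propyl group where compound 1 has cyclopentyl.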